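Aryl swap on the shared core: compound 2 to compound 3

This account rests on a few compounds, and the source may have more. Where it says the series, first, only, none or still open, it means among the compounds named here.

Measured so far:
compound 1 `CC(=O)Nc1cccc(C2CCN(CCCn3c(-c4cccc(C(F)(F)F)c4)nc4ccccc43)CC2)c1` gives 30 nM
compound 2 `COc1ccccc1-c1nc2ccccc2n1CCCN1CCC(c2cccc(NC(C)=O)c2)CC1` gives 747 nM

Compound 2 stands at the weaker end of the two numbers measured in an assay for displacement of a labelled ligand from melanin-concentrating hormone receptor 1 (Homo sapiens), read by fluorescence; a lower number here means a stronger inhibitor, a higher number a weaker inhibitor: compound 1 gives 30 nM, and the step of a 25-fold higher number from compound 1 to compound 2 (1.40 log units; beyond the scatter) is large. That step is the only measured one and is the sole point of reference for compound 3 `CCc1ccc(-c2nc3ccccc3n2CCCN2CCC(c3cccc(NC(C)=O)c3)CC2)cc1`, which is still to be measured. The change from compound 2 to compound 3 is 4-ethylphenyl in place of 2-methoxyphenyl on an aromatic carbon. It alters the same aryl group as the step from compound 1 to compound 2, so that step bears on it; it showed that exchanging this aryl ring moves the number strongly. Among the compounds with values here, compound 3 carries neither the group of compound 1 nor that of compound 2, so the direction is not fixed by the data; the one step shows the group of compound 2 as the weaker of the two known options, which leaves room for a lower number. For compound 3 a moderate decrease is expected, a 3.7-fold lower number from compound 2 to compound 3 (0.57 log units; beyond the scatter), with wide uncertainty. The estimate for compound 3 in this assay is 200 nM, between 50 nM and 800 nM.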

Compound 3, half-maximal inhibitory concentration: 32 nM
Compound 3: middle estimate off by 6.3-fold (0.80 log units), on the high side; the measured number lies below the stated range.
By their numbers in this assay, from the lowest: compounds 1 and 3 (each within the scatter of the next); then compound 2.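

In this assay, the step of a 23-fold lower number from compound 2 to compound 3 (1.37 log units; beyond the scatter) is large and runs opposite to the earlier step of a 25-fold higher number from compound 1 to compound 2 (1.40 log units; beyond the scatter), so a lower number at this position is not tied to the 3-(trifluoromethyl)phenyl group of compound 1. The step of a 1.1-fold higher number from compound 1 to compound 3 (0.03 log units; within the scatter) lies within the scatter, which leaves 4-ethylphenyl and 3-(trifluoromethyl)phenyl indistinguishable here even though they carry different substituents at different ring positions, and among these three compounds only the 2-methoxyphenyl group stands apart. Nothing on hand accounts for the large shift seen with 2-methoxyphenyl.

Compound 2 differs from compound 1 and compound 3 both in its substituent and in where that substituent sits on the phenyl ring, so these compounds cannot separate the effect of the methoxy group itself from that of its ring position. On these data alone, how an unsubstituted phenyl ring, or a phenyl ring bearing an amine or a carboxylic acid, would compare at this position also remains open.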